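From methylsulfonyl to methoxycarbonyl at the assay limit

The source may report more compounds than this note shows. Statements on the series, on what has been measured and on what is new or still open speak of the compounds shown alone.

Measured in an ADME assay on SK-N-BE(2)-M17 cells (Homo sapiens) for cytotoxicity; on this read-out lower numbers stand for higher toxicity in this test and higher numbers for lower toxicity in this test:
Compound 1 `C[C@@H]1CC(C)(C)Nc2c(C(=O)NC/C=C/S(C)(=O)=O)cccc21` gives > 25000 nM
Compound 2 `C[C@@H]1CC(C)(C)Nc2c(C(=O)N[C@@H](C)/C=C/S(C)(=O)=O)cccc21` gives > 25000 nM

In this assay compound 2 stands at > 25000 nM as a limit of the assay, not a number. Compound 1 also gives > 25000 nM as a limit.

The next compound is compound 3 `COC(=O)/C=C/CNC(=O)c1cccc2c1NC(C)(C)C[C@H]2C`, and the change sits on an amide-type nitrogen: 3-(methoxycarbonyl)prop-2-en-1-yl in place of 1-methyl-3-(methylsulfonyl)prop-2-en-1-yl on an amide-type nitrogen. Within the data shown here, the only measured step that bears on it is a step that the two limits leave unreadable from compound 1 to compound 2, which covers methyl in place of hydrogen on the chain. Among the measured compounds shown here, the data hold no measured step for methoxycarbonyl against methylsulfonyl. All they offer is the limit of > 25000 nM in this assay, at which 2 of the 2 values shown sit, and this gives no size to carry over. For the measured compounds named here, with no sized step to draw on, no change beyond the scatter is expected, so the estimated step is a number no higher from compound 2 to compound 3 (the limit leaves the size open) in this assay, though a lower number cannot be ruled out. Compound 3 is expected at an estimated 25000 nM, within a range of 9000 nM to 40000 nM, and it may well report only a limit.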

Compound 3, half-maximal cytotoxic concentration: 11000 nM
Compound 3: middle estimate off by 2.3-fold (0.36 log units), on the high side; the range from low to high includes it.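

In this assay, among these compounds, compound 3 gives the only value shown that is a number and not a limit, so a change at the end of the chain on the amide-type nitrogen can now be seen in this read-out. Methoxycarbonyl in place of methylsulfonyl gives an at least 2.2-fold lower number from compound 1 to compound 3 (0.35 log units; beyond the scatter) and this single exchange stands beyond the scatter, as does the exchange of the whole group, which also loses the chain methyl and gives an at least 2.2-fold lower number from compound 2 to compound 3 (0.35 log units; beyond the scatter) in the same assay. The step between the two methylsulfonyl compounds cannot be read, and the limit still governs most of the data: the limit of > 25000 nM in this assay, at which 2 of the 3 values shown sit.

As far as these compounds go, both readable steps are bounded on one side only, so their full size stays open. From the compounds shown here alone, it is also open how a carboxylic acid or an amide at the same chain end would read, or what the chain methyl does alongside methoxycarbonyl.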